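Aryl Swap on the Piperazine Nitrogen, Compound 4 Awaited

This account rests on a few compounds, and the source may have more. Where it says the series, first, only, none or still open, it means among the compounds named here.

Three compounds share one core and have been measured in an assay on CHO cells for displacement of a labelled ligand from adenosine receptor A3 (Homo sapiens), read by scintillation counting, with a stated time of 120 min, tested at 10 uM; a lower number here means less inhibition, a higher number more inhibition at the concentration tested (going by the name of the read-out):

Compound 1, `Nc1scc(CN2CCN(c3ccc([N+](=O)[O-])cc3)CC2)c1C(=O)c1ccc(Cl)cc1`: 2%
Compound 2, `Nc1scc(CN2CCN(c3ccc(OC(F)(F)F)cc3)CC2)c1C(=O)c1ccc(Cl)cc1`: 1%
Compound 3, `Nc1scc(CN2CCN(c3cc(F)ccc3F)CC2)c1C(=O)c1ccc(Cl)cc1`: 2%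

On the numbers shown, compound 2 carries the smallest figure of the three, yet this says little: the step of a number 1 percentage points lower from compound 1 to compound 2 (within the scatter) and the step of a number 1 percentage points higher from compound 2 to compound 3 (within the scatter) both lie within the scatter, as does the step of no change at the digits printed from compound 1 to compound 3 (within the scatter), so the three compounds cannot be told apart in this assay. All three sit at the floor of the read-out.

Compound 4, `Nc1scc(CN2CCN(c3ccc(F)c(Cl)c3)CC2)c1C(=O)c1ccc(Cl)cc1`, is the next member of the series. It differs from compound 2 in one place: 3-chloro-4-fluorophenyl in place of 4-(trifluoromethoxy)phenyl on an amine nitrogen in a ring. Among the compounds with values here, the steps that bear on this change are those that also exchange the aryl group on the ring nitrogen, namely the step from compound 1 to compound 3 and the step from compound 2 to compound 3, and both were within the scatter. Because the step of a number 1 percentage points higher from compound 2 to compound 3 (within the scatter) showed no movement beyond the scatter, the step of a number 1 percentage points higher from compound 2 to compound 4 (within the scatter) is expected to be of the same kind, with no direction beyond the noise. Compound 4 is therefore estimated at 2% in this assay, within a range from 0% to 12%.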

Compound 4, a percentage reported as inhibition, at one concentration (the size of the read-out at that concentration, not a potency): 0%
Compound 4: middle estimate off by 2 percentage points, on the high side; the range from low to high includes it.
By their numbers in this assay, from the lowest: compounds 4, 2, 1 and 3 (each within the scatter of the next).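

In this assay, placing 3-chloro-4-fluorophenyl on the amine nitrogen in the ring gave a number 1 percentage points lower from compound 2 to compound 4 (within the scatter), and the comparisons with the other two aryl groups gave a number 2 percentage points lower from compound 3 to compound 4 (within the scatter) and a number 2 percentage points lower from compound 1 to compound 4 (within the scatter). This extends the earlier picture to a fourth aryl group, one that carries chlorine and has fewer heavy atoms and no hydrogen-bond acceptor compared with the 4-(trifluoromethoxy)phenyl it replaces, and still none of the four compounds can be told apart at this position. No supporting measurement is available to explain this flat result.

What the compounds shown leave open is whether anything other than a directly attached substituted phenyl ring, such as a benzyl group, a pyridine or a short alkyl chain on that ring nitrogen, would move the read-out beyond the scatter. They also leave open whether these aryl exchanges would separate at all on a version of the shared core that gives a clear signal in this assay, since all four values here lie too close together to rank.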